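This account rests on a few compounds, and the source may have more. Where it says the series, first, only, none or still open, it means among the compounds named here.

Measured in an ADME assay on HEK-293T cells (Homo sapiens) for cytotoxicity, read by CCK-8 assay, with a stated time of 48 h; on this read-out higher numbers stand for weaker inhibition and lower numbers for stronger inhibition:
compound 1 `O=C(NCCNS(=O)(=O)c1cc(-c2ccccc2Oc2ccc(O)c(O)c2)cs1)Nc1cc(C(F)(F)F)cc(C(F)(F)F)c1` — > 50000 nM
compound 2 `O=[N+]([O-])c1ccc(Oc2ccc(O)c(O)c2)c(-c2ccsc2S(=O)(=O)N2CCN(C(=S)Nc3cc(C(F)(F)F)cc(C(F)(F)F)c3)CC2)c1` — > 20000 nM
compound 3 `O=S(=O)(NCCNC(=S)Nc1cc(C(F)(F)F)cc(C(F)(F)F)c1)c1ccc(-c2ccccc2OCc2ccccc2)s1` gives 8500 nM in this assay.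

In this assay the value of compound 1 is a limit, namely (the limit of > 50000 nM in this assay, at which 1 of the 3 values shown sits). For compound 2 the value in this assay is likewise a limit, namely (the limit of > 20000 nM in this assay, at which 1 of the 3 values shown sits). Within the data shown here, compound 3 is therefore the one member of the three that returns a number rather than a limit in this assay, and it is the reference for the next step. Compound 4 `O=S(=O)(NCCNC(=S)Nc1cc(C(F)(F)F)cc(C(F)(F)F)c1)c1ccc(-c2ccccc2O[C@H]2CC[C@@H](O)CC2)s1` differs from it in one place: 4-hydroxycyclohexyl in place of benzyl on an oxygen on an aromatic ring. Among the measured compounds shown here, no step between two measured compounds covers a change of this kind, so the direction in this assay is open; a modest shift toward weaker inhibition, possibly not beyond the usual scatter, is expected, a 1.8-fold higher number from compound 3 to compound 4 (0.25 log units; within the scatter). Compound 4 is expected to give 15000 nM in this assay, within 5000 nM to 45000 nM.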

Compound 4, half-maximal inhibitory concentration: > 20000 nM
Compound 4: a limit, no number (the forecaster's own chance of this, stated with the estimate: 35%); middle value at least 1.3-fold (0.12 log units) away from the limit.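

Among these compounds, putting 4-hydroxycyclohexyl in place of benzyl on an oxygen on an aromatic ring gives the first readable step at this position in this assay, with an at least 2.3-fold higher number from compound 3 to compound 4 (0.37 log units; beyond the scatter). Compound 4 gives > 20000 nM, a limit and not a number, so the step sets only a minimum size: the limit of > 20000 nM in this assay, at which 2 of the 4 values shown sit. This holds for this one pair only.

The compounds shown do not separate the loss of the aromatic ring from the gain of the hydroxy group. A plain cyclohexyl or a 4-aminocyclohexyl on the same oxygen would bear on that.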